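Chloro for methyl: expected cytotoxicity of compound 3

The source may report more compounds than this note shows. Statements on the series, on what has been measured and on what is new or still open speak of the compounds shown alone.

In an ADME assay on L6 cells (Rattus norvegicus) for cytotoxicity, read by resazurin assay, with a stated time of 72 h (on this read-out higher numbers stand for weaker inhibition and lower numbers for stronger inhibition), compound 1 (`OC(c1ccc(Cl)cc1)(c1cccnc1)c1ccc(Cl)cc1F`) gives 59400 nM and compound 2 (`Cc1ccc(C(O)(c2ccc(OC(C)C)cc2)c2cccnc2)c(F)c1`) gives 62600 nM, so compound 2 stands within the scatter of compound 1. Compound 3 (`CC(C)Oc1ccc(C(O)(c2cccnc2)c2ccc(Cl)cc2F)cc1`) has chloro in place of methyl on an aromatic carbon of compound 2: chloro in place of methyl on an aromatic carbon. Among the measured compounds shown here, no measured pair isolates this change. Compound 1, at 59400 nM, also carries the 4-chloro-2-fluorophenyl, so no shift beyond the scatter is expected in this assay. The expected step is a 1.1-fold lower number from compound 2 to compound 3 (0.06 log units; within the scatter), with no firm direction. The estimate for compound 3 is 55000 nM, within a range of 27000 nM to 110000 nM.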

Compound 3, half-maximal inhibitory concentration: 56000 nM
Beside the measured number, compound 3's estimate is 1.0-fold (0.01 log units) below it; the measured number falls inside the stated range.
By their numbers in this assay, from the lowest: compounds 3, 1 and 2 (each within the scatter of the next).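

In this assay, 2-fluoro-4-methylphenyl to 4-chloro-2-fluorophenyl gives a 1.1-fold lower number from compound 2 to compound 3 (0.05 log units; within the scatter), so this pair does not separate chloro from methyl at this position. Isopropoxy in place of chloro on an aromatic carbon gives a 1.1-fold lower number from compound 1 to compound 3 (0.03 log units; within the scatter), so that second place shows no separation either. No supporting data bear on why these numbers stay together.

On these data alone, whether an amine or a carboxylic acid at either place would move the number beyond the scatter remains open. So does whether a longer chain in place of isopropoxy would read the same.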